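The source may report more compounds than this note shows. Statements on the series, on what has been measured and on what is new or still open speak of the compounds shown alone.

Measured in an assay on HEK293 cells for displacement of a labelled ligand from NPC1-like intracellular cholesterol transporter 1 (Homo sapiens); a lower number here means a stronger inhibitor, a higher number a weaker inhibitor:
- compound 1 `CC(C)(C)c1ccc(C(=O)N2CCC3(CC2)C(=O)N(CC(=O)N2CCC(CCO)CC2)CN3c2ccccc2)cc1`: 2600 nM
- compound 2 `CC(C)(C)OC(=O)NCNC(=O)CN1CN(c2ccccc2)C2(CCN(C(=O)c3ccc(C4CCCCC4)cc3)CC2)C1=O`: 1700 nM
- compound 3 `CC(C)(C)c1ccc(C(=O)N2CCC3(CC2)C(=O)N(CC(=O)NCCCN)CN3c2ccccc2)cc1`: 4200 nM

Compound 3 stands apart from compound 2, whose number is lower by a margin beyond the scatter; compound 1 lies within the scatter of compound 3, so no order between those two can be read.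

Compound 4 `CC(C)(C)c1ccc(C(=O)N2CCC3(CC2)C(=O)N(CC(=O)NCCCCNS(C)(=O)=O)CN3c2ccccc2)cc1` is not yet measured. It differs from compound 3 in one place: (methanesulfonamido)methyl in place of amino on a saturated chain carbon, three bonds along the chain from an amide-type nitrogen.

Within the data shown here, only one measured step touches this chain region, a 1.6-fold higher number from compound 1 to compound 3 (0.21 log units; within the scatter), which exchanged the whole group on the carbonyl carbon and yet stayed within the scatter. Among the measured compounds shown here, compound 2, which carries a carbamate-capped amine at a related position, shows a lower number than compound 3, but no single-point step connects the two, so its value gives only a loose hint. Compound 4 is therefore expected to show a 1.5-fold lower number from compound 3 to compound 4 (0.18 log units; within the scatter), a small move toward a lower number, most likely inside the scatter. For compound 4 the estimate in this assay is 2800 nM, with a range from 1000 nM to 8000 nM.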

Compound 4, half-maximal inhibitory concentration: 4500 nM
Compound 4: middle estimate off by 1.6-fold (0.21 log units), on the low side; low and high end bracket the measured number.
By their numbers in this assay, from the lowest: compounds 2, 1, 3 and 4 (each within the scatter of the next, the first and the last beyond it).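

In this assay, the exchange at this chain carbon reads as a 1.1-fold higher number from compound 3 to compound 4 (0.03 log units; within the scatter), so the amino group of compound 3 can give way to the much larger (methanesulfonamido)methyl group, with the same hydrogen-bond donor count and no net charge on either, without a readable shift. The wider exchange on the carbonyl carbon, a 1.7-fold higher number from compound 1 to compound 4 (0.24 log units; within the scatter), also stays within the scatter, so the 4-(2-hydroxyethyl)piperidin-1-yl group and the (4-(methanesulfonamido)butyl)amino group cannot be ordered. Nothing on hand explains why these exchanges leave the number in place.

Still open, going by these compounds, is whether a carboxylic acid on the same saturated chain carbon, or a morpholine on the carbonyl carbon, would move the number beyond the scatter. Compound 2 differs from the others in more than one place, so what sets its value apart cannot be read.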